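A few compounds are considered here, and "the series" means these few. Any claim that something is new, unique, unknown or untested is made for them only; others in the source may bear on it.

Compound 3 `COC(=O)c1cc(-c2cccc(NC(=O)c3ccc(/C=C/C(=O)c4ccc(F)cc4)cc3)c2)on1` belongs to a small set of compounds sharing one core, all examined in an ADME assay on Vero cells (Chlorocebus sabaeus) for cytotoxicity, read by MTT assay, with a stated time of 72 h; a lower number here means that less compound is tolerated, a higher number that more compound is tolerated. In this assay compound 3 gives > 20 ug/mL, which is a limit of the assay rather than a number. Compound 1 `COC(=O)c1cc(-c2cccc(NC(=O)c3ccc(/C=C/C(=O)c4cccc(F)c4)cc3)c2)on1` gives > 40 ug/mL in this assay, again a limit. Compound 2 `COC(=O)c1cc(-c2cccc(NC(=O)c3ccc(/C=C/C(=O)c4cc(OC)c(OC)c(OC)c4)cc3)c2)on1` gives > 50 ug/mL in this assay, once more a limit. Compound 3 thus sits at one of three limits (the limit of > 20 ug/mL in this assay, at which 1 of the 3 values shown sits, (the limit of > 40 ug/mL in this assay, at which 1 of the 3 values shown sits), (the limit of > 50 ug/mL in this assay, at which 1 of the 3 values shown sits)), and no order among the three compounds can be read. The measured steps a step that the two limits leave unreadable from compound 1 to compound 2, a step that the two limits leave unreadable from compound 1 to compound 3 and a step that the two limits leave unreadable from compound 2 to compound 3 are all unreadable for the same reason. Compound 4 `COC(=O)c1cc(-c2cccc(NC(=O)c3ccc(/C=C/C(=O)c4ccccc4Br)cc3)c2)on1` differs from compound 3 in one place: 2-bromophenyl in place of 4-fluorophenyl on a carbonyl carbon. For the measured compounds named here, no measured step gives a size for such an exchange of the group on the carbonyl carbon, since every such exchange so far left tolerance at a limit. The step that the limit leaves unreadable from compound 3 to compound 4 is therefore expected to be small or absent. Compound 4 is expected to give 40 ug/mL, within 15 ug/mL to 100 ug/mL.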

Compound 4, half-maximal cytotoxic concentration: > 40 ug/mL
Compound 4: a limit, no number; the forecaster's own chance of this, stated with the estimate: 70%; the middle value lies on the limit itself.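

Compound 4 gives > 40 ug/mL in this assay, which is a limit of the assay. Its steps from compound 1, compound 2 and compound 3 therefore cannot be read. The compounds shown leave open whether exchanging the group on the carbonyl carbon changes tolerance at all, and by how much.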